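Trifluoromethyl to nitro: a small step expected

The source may report more compounds than this note shows. Statements on the series, on what has been measured and on what is new or still open speak of the compounds shown alone.

Measured in an ADME assay on MCF7-DOX cells (Homo sapiens) for cytotoxicity, read by MTT assay, with a stated time of 48 h (a lower number here means a stronger inhibitor, a higher number a weaker inhibitor), for three compounds:
Compound 1 `COc1cc(OC)c(C(=O)/C=C/c2ccc(C(F)(F)F)cc2)c(O)c1CC=C(C)C` gives 73700 nM
Compound 2 `COc1cc(OC)c(C(=O)/C=C/c2cccc(N3CCNCC3)c2)c(O)c1CC=C(C)C` gives 99900 nM
Compound 3 `COc1cc(OC)c(C(=O)/C=C/c2cccc(C(F)(F)F)c2)c(O)c1CC=C(C)C` gives 66600 nM

Compound 3 sits level with the other two, within the scatter of each. Compound 4 `COc1cc(OC)c(C(=O)/C=C/c2cccc([N+](=O)[O-])c2)c(O)c1CC=C(C)C` keeps the shared core and differs from compound 3 by one swap, nitro in place of trifluoromethyl on an aromatic carbon. Going by the values given here, no measured step makes this exact swap. Among the compounds with values here, two steps bear on it: one exchanges a group on an aromatic carbon (a 1.5-fold lower number from compound 2 to compound 3 (0.18 log units; within the scatter)) and one moves the trifluoromethyl (a 1.1-fold lower number from compound 1 to compound 3 (0.04 log units; within the scatter)). Both stay within the scatter, so no step beyond the scatter is expected in this assay here. The expected change is small (a 1.1-fold higher number from compound 3 to compound 4 (0.02 log units; within the scatter)). The estimate for compound 4 is 70000 nM within an expected range (35000 nM to 120000 nM).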

Compound 4, half-maximal inhibitory concentration: 57000 nM
For compound 4 the middle estimate is 1.2-fold (0.09 log units) above the measured one, and the stated range covers the measured number.
By their numbers in this assay, from the lowest: compounds 4, 3, 1 and 2 (each within the scatter of the next).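

In this assay, nitro takes the place of trifluoromethyl on this aromatic carbon without a shift beyond the scatter (a 1.2-fold lower number from compound 3 to compound 4 (0.07 log units; within the scatter)). The comparisons with the other two compounds also stay within the scatter (a 1.8-fold lower number from compound 2 to compound 4 (0.24 log units; within the scatter); a 1.3-fold lower number from compound 1 to compound 4 (0.11 log units; within the scatter)). Nitro, trifluoromethyl and piperazin-1-yl on this carbon therefore give numbers that cannot be told apart here, and moving from 4-(trifluoromethyl)phenyl to 3-nitrophenyl changes no more.

From the compounds shown here alone, whether a carboxylic acid or a nitrile on this carbon would produce a step beyond the scatter remains open. No measurement shown explains why these groups read alike.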